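The source may report more compounds than this note shows. Statements on the series, on what has been measured and on what is new or still open speak of the compounds shown alone.

Compound 1 `CCOC(=O)/C=C/c1ccncc1-c1ccc2ccccc2c1`: 53.3 nM
Compound 2 `COC1CN(C(=O)/C=C/c2ccncc2-c2ccc3ccccc3c2)C1`: 42.8 nM
Compound 3 `O=C(O)CCNC(=O)/C=C/c1ccncc1-c1ccc2ccccc2c1`: 870 nM

All three compounds share one core and differ only in the group on the carbonyl carbon of the side chain. In an assay on a protein complex for inhibition of CDK8/Cyclin C (Homo sapiens), with a stated time of 1 h (a lower number here means a stronger inhibitor, a higher number a weaker inhibitor), compound 1 gives 53.3 nM, the second highest of the three numbers. Compound 2 stands nearest, with a 1.2-fold lower number from compound 1 to compound 2 (0.10 log units; within the scatter), and compound 3 stands furthest, with a 16-fold higher number from compound 1 to compound 3 (1.21 log units; beyond the scatter).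

Compound 4 `O=C(O)CCc1ccncc1-c1ccc2ccccc2c1` has not yet been measured. It differs from compound 1 in that (2-carboxyethyl in place of 2-(ethoxycarbonyl)ethenyl on an aromatic carbon).

Among the compounds with values here, two measured steps bear on this change, since both introduce a carboxylic acid at the end of the side chain: a 16-fold higher number from compound 1 to compound 3 (1.21 log units; beyond the scatter) and a 20-fold higher number from compound 2 to compound 3 (1.31 log units; beyond the scatter). Both steps were large and pointed toward weaker inhibition. Compound 4 also ends in a carboxylic acid, though here the 2-carboxyethyl group sits directly on the aromatic carbon rather than being joined through an amide, so the measured steps are only a partial guide. A step in the same weakening direction is expected, a 9.4-fold higher number from compound 1 to compound 4 (0.97 log units; beyond the scatter). Compound 4 is therefore estimated at 500 nM in this assay, with the expected range running from 150 nM to 2000 nM.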

Compound 4, half-maximal inhibitory concentration: 50.5 nM
Estimate against measurement, compound 4: 9.9-fold (1.00 log units) above; the measured number lies below the stated range.
By their numbers in this assay, from the lowest: compounds 2, 4 and 1 (each within the scatter of the next); then compound 3.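

In this assay, putting 2-carboxyethyl in place of 2-(ethoxycarbonyl)ethenyl on this aromatic carbon, opposite the ring nitrogen, gives a 1.1-fold lower number from compound 1 to compound 4 (0.02 log units; within the scatter) and so leaves the number within the scatter, which shows that this smaller side chain, with its carboxylic acid at the end and one double bond fewer, is tolerated at this position. A carboxylic acid at the end of the side chain therefore does not by itself go with a weaker number: the large step of a 16-fold higher number from compound 1 to compound 3 (1.21 log units; beyond the scatter) belongs to a side chain that also holds an amide and keeps its carbon-carbon double bond, and the acid alone cannot account for it. Nothing measured here gives a reason for the contrast between these two steps.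

The compounds shown do not separate the effect of the amide from that of the carbon-carbon double bond in compound 3. On these data alone, it also remains open how this position responds when the chain of compound 4 ends in an amine or a hydroxyl group instead of the carboxylic acid, or when that chain is made longer.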